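Swapping a Benzyl for a Benzoyl on the Ring Nitrogen

A few compounds are considered here, and "the series" means these few. Any claim that something is new, unique, unknown or untested is made for them only; others in the source may bear on it.

Measured compounds:
compound 1 `[O-][S+](CCNC1CCN(Cc2ccc(F)cc2)CC1)C(c1ccc(F)cc1)c1ccc(F)cc1`: 26.5 nM
compound 2 `O=C(c1cc2ccccc2o1)N1CCC(NCCSC(c2ccc(F)cc2)c2ccc(F)cc2)CC1`: 304 nM
compound 3 `O=C(c1cc2ccccc2[nH]1)N1CCC(NCCSC(c2ccc(F)cc2)c2ccc(F)cc2)CC1`: 1130 nM

In an assay on membranes from Cortex for displacement of a labelled ligand from Sigma non-opioid intracellular receptor 1 (Cavia porcellus), read by scintillation counting, with a stated time of 120 min (a higher number here means a weaker inhibitor, a lower number a stronger inhibitor), compound 1 gives the lowest number of the three, and its gaps to compound 2 and compound 3 both lie beyond the scatter, so it is the strongest inhibitor shown. Compound 4 `O=C(c1ccccc1)N1CCC(NCC[S+]([O-])C(c2ccc(F)cc2)c2ccc(F)cc2)CC1` differs from compound 1 in one place: benzoyl in place of 4-fluorobenzyl on an amine nitrogen in a ring. For the measured compounds named here, no measured step covers exactly this swap. Going by the values given here, the one measured step, a 3.7-fold higher number from compound 2 to compound 3 (0.57 log units; beyond the scatter), concerns the group on the carbonyl carbon, not the exchange of a benzyl for a benzoyl. Compound 2 and compound 3, which carry a carbonyl on that ring nitrogen but also differ from compound 1 elsewhere, give clearly higher numbers. On that basis a higher number is expected for compound 4, a step of a 5.7-fold higher number from compound 1 to compound 4 (0.75 log units; beyond the scatter). The estimate for compound 4 is 150 nM, within 40 nM to 600 nM.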

Compound 4, inhibition constant: 585 nM
For compound 4 the middle estimate is 3.9-fold (0.59 log units) below the measured one, and the stated range covers the measured number.
By their numbers in this assay, from the lowest: compound 1; then compounds 2, 4 and 3 (each within the scatter of the next, the first and the last beyond it).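

Compound 1 and compound 4 are the only pair shown that changes this ring nitrogen alone, and benzoyl in place of 4-fluorobenzyl gives a 22-fold higher number from compound 1 to compound 4 (1.34 log units; beyond the scatter) in this assay. For the compounds shown here, compound 2 and compound 3 also carry a carbonyl there, but they differ from compound 1 elsewhere too, so only this pair ties the weaker binding to this position. Nothing measured here gives a reason for the loss. The swap adds a carbonyl and removes a fluorine together, so the compounds shown cannot separate the two. A plain benzyl or a 4-fluorobenzoyl on that nitrogen would pull them apart.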